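The compounds below may be only part of what the source reports. "The series", "measured", "known", "first", "only" and "open" are said of these compounds alone.

Within the data shown here, compound 1 `O=C1NC[C@@](COCc2cc(C(F)(F)F)cc(C(F)(F)F)c2)(c2ccccc2)N1` is one of two compounds measured in an assay on CHO cells for displacement of a labelled ligand from Substance-P receptor (Homo sapiens); on this read-out higher numbers stand for weaker inhibition and lower numbers for stronger inhibition; compound 1 gives 6 nM, the lower of the two numbers, though the gap to compound 2 lies within the scatter. Compound 2 `O=C1NC(COCc2cc(C(F)(F)F)cc(C(F)(F)F)c2)(c2ccc(F)cc2)CN1C1CCOCC1` carries a 4-fluorophenyl group and a tetrahydropyranyl substituent on its core, and in this assay compound 2 gives 6.3 nM. Compound 3 `O=C1NC[C@@](COCc2cc(C(F)(F)F)cc(C(F)(F)F)c2)(c2ccc(F)cc2)N1` follows from compound 1 through a single change: fluoro in place of hydrogen on an aromatic carbon. Among the measured compounds shown here, no step between two measured compounds isolates this change, since compound 2 differs from compound 1 in more than one place, so the comparison of compound 1 with compound 2 shows only that both numbers sit close together. The step from compound 1 to compound 3 is therefore expected to be small, with no direction beyond the scatter, as a 1.2-fold lower number from compound 1 to compound 3 (0.08 log units; within the scatter). Compound 3 is estimated at 5 nM, with a range of 2 nM to 15 nM.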

Compound 3, inhibition constant: 2.7 nM
Compound 3: the middle estimate sits 1.9-fold (0.27 log units) above what was measured; the measured number falls inside the stated range.
By their numbers in this assay, from the lowest: compound 3; then compounds 1 and 2 (each within the scatter of the next).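

In this assay, among these compounds, replacing phenyl with 4-fluorophenyl gives a 2.2-fold lower number from compound 1 to compound 3 (0.35 log units; beyond the scatter) and so provides the first reading of this change on its own, which no earlier pair of compounds could supply. The step is modest but beyond the scatter, showing that on this aromatic carbon, para to a large group, a single fluoro is accepted and accompanies stronger inhibition. No accompanying measurement accounts for the size or direction of this step.

On these data alone, whether a chloro, a methoxy group or a nitrile on the same aromatic carbon would move the number in the same direction remains open, as does the outcome of placing fluoro on another carbon of this ring. Equally open, as far as these compounds go, is whether the step keeps its size once a tetrahydropyranyl substituent sits on the core.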